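A methyl added to the core of compound 1

The compounds below may be only part of what the source reports. "The series", "measured", "known", "first", "only" and "open" are said of these compounds alone.

Measured compounds:
compound 1, `COC(=O)[C@@]1(C)CCC=C2[C@@H]1CC[C@@H](C)[C@]2(C)Cc1c[nH]c2ccccc12`, 7300 nM
compound 2, `COC(=O)[C@@]1(C)CCC=C2[C@@H]1CC[C@@H](C)[C@]2(C)Cc1c[nH]c2ccc(Cl)cc12`, 11000 nM

Of the compounds shown here, two have been measured in a functional assay on SW1573 cells (Homo sapiens) for inhibition, read by sulforhodamine B assay, with a stated time of 48 h; a lower number here means a stronger inhibitor of growth, a higher number a weaker inhibitor of growth. Compound 1 gives 7300 nM, which is the lowest of the two numbers. Its nearest neighbour is compound 2, which gives 11000 nM, and the step of a 1.5-fold higher number from compound 1 to compound 2 (0.18 log units; within the scatter), so the two cannot be told apart.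

Compound 3, `COC(=O)[C@@]1(C)CCC=C2[C@@H]1CC[C@@H](C)[C@]2(C)Cc1c[nH]c2c(C)cccc12`, has not yet been measured. It differs from compound 1 in one place: methyl in place of hydrogen on an aromatic carbon. Among the compounds with values here, the only measured step that bears on this change is the one from compound 1 to compound 2, which likewise alters a single small substituent on the aromatic part of the shared core and gave a 1.5-fold higher number from compound 1 to compound 2 (0.18 log units; within the scatter). On that single precedent, no step beyond the scatter is expected in this assay from adding the methyl.

Compound 3 is therefore expected to give about 8000 nM, with a range from 3500 nM to 18000 nM. The expected step is a 1.1-fold higher number from compound 1 to compound 3 (0.04 log units; within the scatter).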

Compound 3, concentration for 50% growth inhibition: 7800 nM
Compound 3: middle estimate off by 1.0-fold (0.01 log units), on the high side; the measured number falls inside the stated range.
By their numbers in this assay, from the lowest: compounds 1, 3 and 2 (each within the scatter of the next).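

In this assay, methyl in place of hydrogen on an aromatic carbon, ortho to a fused ring and meta to a fused ring, gives a 1.1-fold higher number from compound 1 to compound 3 (0.03 log units; within the scatter) and so adds a second single-substituent step on the aromatic part of the shared core. The earlier step, a 1.5-fold higher number from compound 1 to compound 2 (0.18 log units; within the scatter) for chloro in place of hydrogen, was the only such comparison and lay at a different aromatic carbon; with this result, neither a chloro nor a methyl on the aromatic part gives a step beyond the scatter, and no compound shown goes against that for these two small groups. Nothing available on the compounds explains this result or shows how far it extends beyond them.

Still open, going by these compounds, is whether a group other than methyl on this same carbon, such as an amine, a carboxylic acid or a longer chain like butyl, would give a step beyond the scatter. Also open, on these data alone, is whether a change away from the aromatic part, such as a carboxylic acid in place of the methyl ester, would give one.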